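The compounds below may be only part of what the source reports. "The series", "measured", "known", "first", "only" and "open" are said of these compounds alone.

Compound 1 `O=C(/C=C\Nc1ccc(F)cc1)c1nc(-c2ccc(F)cc2)n2ccccc12` sits in a functional assay on HCT-116 cells (Homo sapiens) for cytotoxicity, read by MTT assay, with a stated time of 48 h (a lower number here means a stronger inhibitor, a higher number a weaker inhibitor), at a limit of the assay rather than a number, giving > 30000 nM. Compound 2 `O=C(/C=C\Nc1cnc2ccccc2c1)c1nc(-c2ccccc2)n2ccccc12` likewise reaches only a limit in this assay, with > 30000 nM. Compound 3 `O=C(/C=C\Nc1ccc(F)cc1)c1nc(-c2ccc(C(F)(F)F)cc2)n2ccccc12`, in turn, gives > 30000 nM, again a limit. Within the data shown here, the one step between measured compounds, a step that the two limits leave unreadable from compound 1 to compound 3, is therefore unreadable, since (the limit of > 30000 nM in this assay, at which 3 of the 3 values shown sit). Compound 4 `COc1ccc(N/C=C\C(=O)c2nc(-c3ccc(F)cc3)n3ccccc23)cc1OC` differs from compound 1 by 3,4-dimethoxyphenyl in place of 4-fluorophenyl on an amine nitrogen. Among the measured compounds shown here, no measured step offers a readable size for this change, so no shift beyond the scatter is expected, and the expected step is a number no higher from compound 1 to compound 4 (the limit leaves the size open). Compound 4 is estimated to give about 30000 nM in this assay, within a range from 8000 nM to 100000 nM.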

Compound 4, half-maximal inhibitory concentration: > 30000 nM
Compound 4: only a limit was reported; the forecaster's own chance of this, stated with the estimate: 70%; the middle value lies on the limit itself.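

In this assay compound 4 gives > 30000 nM as a limit, so the step from compound 1 to compound 4 cannot be read: the limit of > 30000 nM in this assay, at which 4 of the 4 values shown sit. The compounds shown leave open whether any of these substituent changes shifts potency at all.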